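The source may hold more compounds than are shown below. What is called first, only, known or untested is meant among the compounds shown, and "the series" means these compounds.

In a functional assay on HO8910 cells (Homo sapiens) for inhibition, read by MTT assay, with a stated time of 24 h, tested at 1 ug/mL (on this read-out higher numbers stand for more inhibition of growth at the one concentration tested and lower numbers for less inhibition of growth), compound 1 (`O=C(CCCCC(S)CCS)NO`) is reported as "not active" (no number reported) with no number attached. For the measured compounds named here, compound 2 (`O=C(CCCCC(S)CCS)Nc1ccccc1`) gives 6.38% and so holds the only number available, which leaves nothing to rank it against. Compound 3 (`O=C(CCCCC(S)CCS)Nc1ccc(Cl)cc1`) has chloro in place of hydrogen on an aromatic carbon of compound 2, para to a large group (chloro in place of hydrogen on an aromatic carbon). Going by the values given here, no measured pair shows what such a change does, so in this assay only a small rise is expected, with an estimated a number 3.6 percentage points higher from compound 2 to compound 3 (within the scatter) that stays within the usual scatter. Compound 3 is expected to give about 10% with a range from 2% to 25% when measured.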

Compound 3, percent growth inhibition at one concentration: 2.81%
Compound 3: the middle estimate sits 7.2 percentage points above what was measured; the measured number falls inside the stated range.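

Swapping hydrogen for chloro on an aromatic carbon, para to a large group, gives the first readable step in this assay, with a number 3.6 percentage points lower from compound 2 to compound 3 (within the scatter) as the result. On this read-out, the two compounds cannot be told apart, so this single swap at this position shows no clear effect on growth inhibition. Nothing available explains this result. Still open, going by these compounds, is whether an amine or a carboxylic acid in the same place would separate from compound 2. On these data alone, whether any other group there would do so also remains unknown.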